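Sulfonamide nitrogen groups: from compound 3 to compound 4

The source may report more compounds than this note shows. Statements on the series, on what has been measured and on what is new or still open speak of the compounds shown alone.

compound 1 `Cc1cc(C)nc(NS(=O)(=O)c2ccc(Nc3nncc4ccccc34)cc2)n1` gives 3.5 nM
compound 2 `O=S(=O)(Nc1ncccn1)c1ccc(Nc2nncc3ccccc23)cc1` gives 14 nM
compound 3 `O=S(=O)(Nc1nccs1)c1ccc(Nc2nncc3ccccc23)cc1` gives 15 nM

These three values come from a functional assay on HeLa cells (Homo sapiens) for antiproliferative activity, read by sulforhodamine B assay, with a stated time of 72 h (a lower number here means a stronger inhibitor, a higher number a weaker inhibitor), and span a narrow range. Compound 3 sits with compound 2 at the high end of the numbers, and the two do not separate (a 1.1-fold higher number from compound 2 to compound 3 (0.03 log units; within the scatter)). Compound 1 holds the lowest number (a 4.3-fold higher number from compound 1 to compound 3 (0.63 log units; beyond the scatter)).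

Compound 4 `O=S(=O)(Nc1ccccn1)c1ccc(Nc2nncc3ccccc23)cc1` has pyridin-2-yl in place of 1,3-thiazol-2-yl on a sulfonamide nitrogen. The closest measured step is the exchange of pyrimidin-2-yl for 1,3-thiazol-2-yl, which stayed within the scatter (a 1.1-fold higher number from compound 2 to compound 3 (0.03 log units; within the scatter)). Only compound 1, with 4,6-dimethylpyrimidin-2-yl, stands apart (a 4.0-fold higher number from compound 1 to compound 2 (0.60 log units; beyond the scatter)), and compound 4 lacks that group. No step beyond the scatter is therefore expected in this assay for this change, although three compounds are a thin basis. The expected step is small (a 1.1-fold higher number from compound 3 to compound 4 (0.05 log units; within the scatter)). Compound 4 is estimated at 17 nM with 7 nM to 40 nM as the expected range.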

Compound 4, half-maximal inhibitory concentration: 26 nM
Estimate against measurement, compound 4: 1.5-fold (0.18 log units) below, and the stated range covers the measured number.
By their numbers in this assay, from the lowest: compound 1; then compounds 2, 3 and 4 (each within the scatter of the next).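

In this assay pyridin-2-yl on the sulfonamide nitrogen does not separate from 1,3-thiazol-2-yl (a 1.7-fold higher number from compound 3 to compound 4 (0.24 log units; within the scatter)) or from pyrimidin-2-yl (a 1.9-fold higher number from compound 2 to compound 4 (0.27 log units; within the scatter)). A six-membered aromatic ring with one hetero atom therefore reads like both the five-membered ring with two hetero atoms and the pyrimidin-2-yl ring, so compounds 2, 3 and 4 form one group at this position. Compound 1 remains the only one apart, and pyridin-2-yl adds a third step beyond the scatter from its 4,6-dimethylpyrimidin-2-yl group (a 7.4-fold higher number from compound 1 to compound 4 (0.87 log units; beyond the scatter)).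

Nothing available here gives a reason for these steps. Still open, on these data alone, is how a pyrimidin-2-yl ring with a single methyl, a pyridin-2-yl ring with two methyl groups, or an acetyl group on the sulfonamide nitrogen would read.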